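Swapping a Formylphenyl for a Naphthalenyl Group

A few compounds are considered here, and "the series" means these few. Any claim that something is new, unique, unknown or untested is made for them only; others in the source may bear on it.

Among the compounds with values here, only two compounds have been measured so far. In a functional assay on SF-268 cells (Homo sapiens) for inhibition, read by sulforhodamine B assay, with a stated time of 48 h, tested at 10 uM (on this read-out higher numbers stand for more inhibition at the one concentration tested (going by the name of the read-out) and lower numbers for less inhibition), compound 2 `O=Cc1ccc(-c2cn3ccnc3c(-c3ccc4ncn(Cc5ccccc5)c4c3)n2)cc1` gives 27.1%, and it stands within the scatter of compound 1 `CCc1ccc(-c2cn3ccnc3c(-c3ccc4ncn(Cc5ccccc5)c4c3)n2)cc1`, which in this assay gives 30.5%. Within the data shown here, the single measured step, a number 3.4 percentage points lower from compound 1 to compound 2 (within the scatter), touches the same carbon of the shared core. Compound 3 `c1ccc(Cn2cnc3ccc(-c4nc(-c5cccc6ccccc56)cn5ccnc45)cc32)cc1` carries naphthalen-1-yl in place of 4-formylphenyl on an aromatic carbon. Among the measured compounds shown here, no measured step exchanges a whole aromatic group, so the one known step is a weak guide, and the expected change is none beyond the scatter: a number 2.9 percentage points higher from compound 2 to compound 3 (within the scatter). The estimate for compound 3 is therefore 30%, spanning 15% to 45%.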

Compound 3, a percentage reported as inhibition, at one concentration (the size of the read-out at that concentration, not a potency): 10.3%
The estimate for compound 3 lay 19.7 percentage points above the measured number, outside the stated range (below it).
By their numbers in this assay, from the lowest: compound 3; then compounds 2 and 1 (each within the scatter of the next).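

On this aromatic carbon in this assay, naphthalen-1-yl in place of 4-formylphenyl gives a number 16.8 percentage points lower from compound 2 to compound 3 (beyond the scatter) and in place of 4-ethylphenyl gives a number 20.2 percentage points lower from compound 1 to compound 3 (beyond the scatter) so both routes to compound 3 end in a clear loss. The earlier exchange of ethyl for formyl left the phenyl ring in place and stayed within the scatter, whereas replacing the whole phenyl group does move the number. Nothing available explains this loss.

Still open, on these data alone, is whether an amine or a carboxylic acid on the phenyl ring would hold the level of compound 1 and compound 2, and whether naphthalen-2-yl would behave like naphthalen-1-yl.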